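The compounds below may be only part of what the source reports. "The series", "measured", "known", "first", "only" and "open" are said of these compounds alone.

Of the compounds shown here, three built on one shared core have been tested in an ADME assay on MT4 cells (Homo sapiens) for cytotoxicity, read by MTT assay, with a stated time of 4 days; a higher number here means that more compound is tolerated, a lower number that less compound is tolerated. Compound 1 `COc1ccc(-c2cc(C)c(Nc3ccnc(Nc4ccc(C#N)cc4)n3)c(C)c2)cc1` gives 2890 nM, compound 2 `Cc1cc(-c2ccc(C(F)(F)F)cc2)cc(C)c1Nc1ccnc(Nc2ccc(C#N)cc2)n1` gives 4160 nM, and compound 3 `Cc1cc(-c2c(C)cccc2C)cc(C)c1Nc1ccnc(Nc2ccc(C#N)cc2)n1` gives 2590 nM. Compound 3 has the lowest of the three numbers, but the gaps to its neighbours are small: a 1.1-fold lower number from compound 1 to compound 3 (0.05 log units; within the scatter) and a 1.6-fold lower number from compound 2 to compound 3 (0.21 log units; within the scatter), so no real difference between the three can be claimed.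

Compound 4 `Cc1cc(-c2ccc(Cl)cc2)cc(C)c1Nc1ccnc(Nc2ccc(C#N)cc2)n1` has not yet been measured. It differs from compound 3 in a single place: 4-chlorophenyl in place of 2,6-dimethylphenyl on an aromatic carbon. The two steps that bear on this change are the ones in which the same 2,6-dimethylphenyl group enters in place of a differently substituted phenyl ring, and both stayed inside the scatter, as did the step in which one such substituent replaced another, a 1.4-fold higher number from compound 1 to compound 2 (0.16 log units; within the scatter). Every exchange of this ring seen so far has left the cytotoxicity essentially unchanged, so the reverse exchange to a 4-chlorophenyl group is expected to do the same.

In this assay compound 4 is therefore estimated at about 3200 nM, with a likely range from 1600 nM to 6400 nM. The expected step of a 1.2-fold higher number from compound 3 to compound 4 (0.09 log units; within the scatter) is not expected to exceed the scatter.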

Compound 4, half-maximal cytotoxic concentration: 4190 nM
The estimate for compound 4 lay 1.3-fold (0.12 log units) below the measured number; the range from low to high includes it.
By their numbers in this assay, from the lowest: compounds 3, 1, 2 and 4 (each within the scatter of the next).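

In this assay, the exchange at this position now includes a chloro group, and it still gives no step beyond the scatter: chloro in place of trifluoromethyl gives (a 1.0-fold higher number from compound 2 to compound 4 (0.00 log units; within the scatter)), chloro in place of methoxy gives (a 1.4-fold higher number from compound 1 to compound 4 (0.16 log units; within the scatter)), and 4-chlorophenyl in place of 2,6-dimethylphenyl gives (a 1.6-fold higher number from compound 3 to compound 4 (0.21 log units; within the scatter)). The earlier compounds shown here covered only methoxy, trifluoromethyl and two methyl groups on this ring, so compound 4 extends the same finding to a fourth substitution pattern, and the four compounds cannot be told apart in this assay. No measurement shown here offers an explanation for this lack of separation.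

Every group at this position so far is a phenyl ring carrying small substituents, so the compounds shown leave open whether a ring bearing an amine or a carboxylic acid would also stay within the scatter of these four. They also leave open what a group without an aromatic ring, such as a longer alkyl chain, would do on this carbon, and whether changes elsewhere on the shared core would move the number further.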